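Further Methoxy Substitution and Cytotoxicity in Jurkat Cells

This account rests on a few compounds, and the source may have more. Where it says the series, first, only, none or still open, it means among the compounds named here.

Three measured compounds share one core and differ only at one carbonyl carbon. Compound 1 `COC(=O)/C(=C\c1ccc(OC(=O)c2ccccc2)cc1)Sc1ccnc2cc(Cl)ccc12` gives 35700 nM in a functional assay on Jurkat E6.1 cells (Homo sapiens) for cytotoxicity, read by MTT assay, with a stated time of 24 h; a lower number here means a stronger inhibitor, a higher number a weaker inhibitor. Compound 2 `COC(=O)/C(=C\c1ccc(OC(=O)c2ccc(OC)cc2)cc1)Sc1ccnc2cc(Cl)ccc12` gives 11000 nM, and compound 3 `COC(=O)/C(=C\c1ccc(OC(=O)c2ccc(OC)cc2OC)cc1)Sc1ccnc2cc(Cl)ccc12` gives 10200 nM. Among these three numbers compound 2 stands second highest, close to compound 3 and well apart from compound 1. The unmeasured compound 4 `COC(=O)/C(=C\c1ccc(OC(=O)c2cc(OC)c(OC)c(OC)c2)cc1)Sc1ccnc2cc(Cl)ccc12` carries 3,4,5-trimethoxyphenyl in place of 4-methoxyphenyl on a carbonyl carbon. Going by the values given here, two steps bear on this change: a 3.2-fold lower number from compound 1 to compound 2 (0.51 log units; beyond the scatter), and a 1.1-fold lower number from compound 2 to compound 3 (0.03 log units; within the scatter). The first methoxy brought a modest step, while a second gave nothing beyond the scatter, so adding two more is expected to change little. Compound 4 is therefore expected near 9000 nM, between 4000 nM and 20000 nM, an estimated step of a 1.2-fold lower number from compound 2 to compound 4 (0.09 log units; within the scatter).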

Compound 4, half-maximal inhibitory concentration: 4570 nM
Estimate against measurement, compound 4: 2.0-fold (0.29 log units) above; the measured number falls inside the stated range.
By their numbers in this assay, from the lowest: compound 4; then compounds 3 and 2 (each within the scatter of the next); then compound 1.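

In this assay, this carbonyl position still responds after the 2,4-dimethoxyphenyl group, with a 2.2-fold lower number from compound 3 to compound 4 (0.35 log units; beyond the scatter) and a 2.4-fold lower number from compound 2 to compound 4 (0.38 log units; beyond the scatter) as well. Over the whole series, replacing phenyl with 3,4,5-trimethoxyphenyl gives a 7.8-fold lower number from compound 1 to compound 4 (0.89 log units; beyond the scatter) and makes compound 4 the strongest of the four. No measurement shown here explains this gain. On these data alone, whether the count of methoxy groups or their placement matters more stays open, as compound 3 and compound 4 differ in both. As far as these compounds go, how an amine or a carboxylic acid would behave on this ring also stays open.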